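The source may report more compounds than this note shows. Statements on the series, on what has been measured and on what is new or still open speak of the compounds shown alone.

Two compounds share one core and differ only in the group carried on an aromatic nitrogen. Compound 1 `CCCCCC(CCCCC)n1ccc2cc(/C(C)=C/C(=O)Nc3ccccc3OCCCC(=O)O)ccc21` gives 25 nM in an assay on Prostate gland for inhibition of steroid 5-alpha-reductase (Rattus norvegicus); a higher number here means a weaker inhibitor, a lower number a stronger inhibitor. Compound 2 `C/C(=C\C(=O)Nc1ccccc1OCCCC(=O)O)c1ccc2c(ccn2C(C)c2ccccc2)c1` gives 19 nM in this assay and stands nearest to compound 1, the step of a 1.3-fold lower number from compound 1 to compound 2 (0.12 log units; within the scatter) lying within the scatter. Compound 3 `CCCC(c1ccccc1)n1ccc2cc(/C(C)=C/C(=O)Nc3ccccc3OCCCC(=O)O)ccc21` differs from compound 2 by ethyl in place of hydrogen on a saturated chain carbon, two bonds along the chain from an aromatic carbon and an aromatic nitrogen. Going by the values given here, the only measured step that bears on this change, a 1.3-fold lower number from compound 1 to compound 2 (0.12 log units; within the scatter), stayed within the scatter, so no step beyond the scatter is expected in this assay. Compound 3 is therefore estimated at 20 nM, between 8 nM and 50 nM, an expected step of a 1.1-fold higher number from compound 2 to compound 3 (0.02 log units; within the scatter).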

Compound 3, half-maximal inhibitory concentration: 9.1 nM
The estimate for compound 3 lay 2.2-fold (0.34 log units) above the measured number; low and high end bracket the measured number.
By their numbers in this assay, from the lowest: compound 3; then compounds 2 and 1 (each within the scatter of the next).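

In this assay ethyl in place of hydrogen on this saturated chain carbon gives a 2.1-fold lower number from compound 2 to compound 3 (0.32 log units; beyond the scatter) and is the first step shown to pass the scatter. The 1-phenylbutyl group in place of 1-pentylhexyl also passes it, with a 2.7-fold lower number from compound 1 to compound 3 (0.44 log units; beyond the scatter) as its size, so the length of this short chain can matter. Nothing measured here explains the change. On these data alone, whether a longer chain, as in 1-phenylhexyl, would lower the number further stays open, and so does the effect of an amine at the end of the propyl chain.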